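The source may hold more compounds than are shown below. What is called first, only, known or untested is meant among the compounds shown, and "the series" means these compounds.

Working notes on the series. In a functional assay on ACHN cells (Homo sapiens) for cytotoxicity, read by sulforhodamine B assay, tested at 10 uM (on this read-out lower numbers stand for less inhibition and higher numbers for more inhibition at the one concentration tested (going by the name of the read-out)), compound 1 `CC(=O)OC[C@H]1O[C@@H](n2cc(-c3cc(C)no3)c(=O)[nH]c2=O)C[C@@H]1OC(C)=O` gives 96.4%. Compound 2 `CCCc1cc(-c2cn([C@H]3C[C@H](OC(C)=O)[C@@H](COC(C)=O)O3)c(=O)[nH]c2=O)on1` gives 99.5% in this assay, and compound 3 `CCCCCc1cc(-c2cn([C@H]3C[C@H](OC(C)=O)[C@@H](COC(C)=O)O3)c(=O)[nH]c2=O)on1` gives 99.8%. Compound 3 stands at the highest of the three numbers as written, but the three sit close together: the step of a number 3.1 percentage points higher from compound 1 to compound 2 (within the scatter), the step of a number 3.4 percentage points higher from compound 1 to compound 3 (within the scatter) and the step of a number 0.3 percentage points higher from compound 2 to compound 3 (within the scatter) each fall within the scatter, so no order among the three compounds can be read from these numbers. Compound 4 `CCc1ccc(-c2cc(-c3cn([C@H]4C[C@H](OC(C)=O)[C@@H](COC(C)=O)O4)c(=O)[nH]c3=O)on2)cc1` is not yet measured. Its change from compound 3 is 4-ethylphenyl in place of pentyl on an aromatic carbon. Within the data shown here, no measured step involves a ring entering at this position; the three measured steps only vary the length of the chain there, and none moved the read-out beyond the scatter, with all three values near the top of the read-out. On that basis, for compound 4 the expected step is a number 1.3 percentage points lower from compound 3 to compound 4 (within the scatter), not beyond the scatter. Compound 4 is therefore estimated at 98.5%, with a range from 90% to 100%.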

Compound 4, a percentage reported as inhibition, at one concentration (the size of the read-out at that concentration, not a potency): 92%
The estimate for compound 4 lay 6.5 percentage points above the measured number; measured number inside the range.
By their numbers in this assay, from the lowest: compounds 4, 1, 2 and 3 (each within the scatter of the next).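

A ring at this position, on the aromatic carbon next to the ring nitrogen, gives no readable change in this assay: the steps of a number 7.8 percentage points lower from compound 3 to compound 4 (within the scatter) and a number 7.5 percentage points lower from compound 2 to compound 4 (within the scatter) and a number 4.4 percentage points lower from compound 1 to compound 4 (within the scatter) show that 4-ethylphenyl, with its six-membered aromatic ring of carbon only, can stand in place of pentyl, propyl or methyl without leaving the scatter. Among these compounds, compound 4 therefore cannot be placed in any order against compounds 1, 2 and 3, so the series so far shows no separation between ring and chain here. Nothing at hand bears on the reason for these numbers.

As far as these compounds go, whether a plain phenyl, a pyridine ring, or a phenyl carrying an amine or a carboxylic acid would move the read-out beyond the scatter stays open. Any differences among the four in the size of the effect at other concentrations, which a single tested concentration cannot give, also stay open.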